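The source may report more compounds than this note shows. Statements on the series, on what has been measured and on what is new or still open speak of the compounds shown alone.

Compound 3 `C[C@@]1(O)[C@H](O)[C@@H](CO)O[C@H]1n1cnc2c(N)nc(O)nc21` is one of three closely related compounds examined for cytotoxicity. In an ADME assay on PBMC cells (Homo sapiens) for cytotoxicity, read by trypan blue exclusion, with a stated time of 6 days (on this read-out higher numbers stand for lower toxicity in this test and lower numbers for higher toxicity in this test), compound 3 stands only at an assay limit, > 100000 nM. Compound 1 `C[C@@]1(O)[C@H](O)[C@@H](CO)O[C@H]1n1cnc2c(N=[N+]=[N-])nc(N)nc21` likewise gives only a limit in this assay, > 100000 nM. Compound 2 `COc1nc(O)nc2c1ncn2[C@@H]1O[C@H](CO)[C@@H](O)[C@@]1(C)O` also stops at a limit in this assay, > 100000 nM. Among the compounds with values here, the single measured step between neighbours, a step that the two limits leave unreadable from compound 2 to compound 3, cannot be read in size; the feature shared by all three is the limit of > 100000 nM in this assay, at which 3 of the 3 values shown sit. Compound 4 `CONc1nc(N)c2ncn([C@@H]3O[C@H](CO)[C@@H](O)[C@@]3(C)O)c2n1` differs from compound 3 by methoxyamino in place of hydroxy on an aromatic carbon. Within the data shown here, no measured step bears on this change with a readable size, so no direction can be drawn, and the expectation is that compound 4 again sits at the limit. Compound 4 is therefore estimated at 100000 nM, with a range from 50000 nM to 300000 nM. The expected step is a number no higher from compound 3 to compound 4 (the limit leaves the size open), none beyond the scatter.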

Compound 4, half-maximal cytotoxic concentration: > 100000 nM
Compound 4 was reported as a limit (the forecaster's own chance of this, stated with the estimate: 85%); the middle value lies on the limit itself.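

Compound 3 and compound 4 both stop at a limit, so the step between them cannot be read in size. The compounds shown leave open how any change on the shared core alters the read-out in this assay, as all of them stop at the same point: the limit of > 100000 nM in this assay, at which 4 of the 4 values shown sit.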